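Hydroxy for Methylamino: Cytotoxicity Expected to Stay Undetectable

A few compounds are considered here, and "the series" means these few. Any claim that something is new, unique, unknown or untested is made for them only; others in the source may bear on it.

Compound 2 `CNc1ccnc2c1ncn2[C@@H]1O[C@H](CO)[C@](O)(CN=[N+]=[N-])[C@H]1O` carries a methylamino group on the shared core. In an ADME assay on Huh-7 cells (Homo sapiens) for cytotoxicity, read by WST assay, with a stated time of 3 days (a higher number here means that more compound is tolerated, a lower number that less compound is tolerated), compound 2 reaches only the limit of the test, > 100000 nM. Its nearest neighbour, compound 1 `[N-]=[N+]=NC[C@@]1(O)[C@@H](CO)O[C@@H](n2cnc3c(N)ccnc32)[C@@H]1O`, keeps a hydrogen where compound 2 has the methyl. In this assay compound 1 likewise ends at a limit, > 100000 nM. The step that the two limits leave unreadable from compound 1 to compound 2 therefore cannot be read in size or direction, since both measured values rest at the limit of > 100000 nM in this assay, at which 2 of the 2 values shown sit. For the measured compounds named here, compound 2 thus stands at a limit, and the one further value shown is a limit too; no number places it anywhere in particular.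

Compound 3 `[N-]=[N+]=NC[C@@]1(O)[C@@H](CO)O[C@@H](n2cnc3c(O)ccnc32)[C@@H]1O` differs from compound 2 by hydroxy in place of methylamino on an aromatic carbon. Going by the values given here, no measured step in this set bears on that exchange; the only step known, a step that the two limits leave unreadable from compound 1 to compound 2, touches the same nitrogen but is unreadable. With both measured values at the limit of > 100000 nM in this assay, at which 2 of the 2 values shown sit, compound 3 is expected to give 100000 nM, between 50000 nM and 300000 nM, most probably again as a limit. The expected step of a number no higher from compound 2 to compound 3 (the limit leaves the size open) is accordingly none beyond the scatter.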

Compound 3, half-maximal cytotoxic concentration: > 100000 nM
Compound 3 gave a limit, no number (the forecaster's own chance of this, stated with the estimate: 85%); the middle value sits exactly at the limit.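

For the compounds shown here, compound 3 ends at a limit in this assay as compound 1 and compound 2 do, so no step among the three can be read in size or direction: the limit of > 100000 nM in this assay, at which 3 of the 3 values shown sit. The compounds shown leave open at what concentration any of them would harm these cells, and whether amino, methylamino or hydroxy would then make any difference.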